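This account rests on a few compounds, and the source may have more. Where it says the series, first, only, none or still open, it means among the compounds named here.

Compound 1 `CC(C)c1ccc(Oc2ccc(O)c(O)c2)c(-c2ccsc2S(=O)(=O)NCCNC(=S)Nc2cc(C(F)(F)F)cc(C(F)(F)F)c2)c1` was tested in an assay for binding affinity to Apoptosis regulator Bcl-2 (Homo sapiens), read by fluorescence polarization, with stated times of 30 min and 20 min (on this read-out lower numbers stand for stronger inhibition and higher numbers for weaker inhibition), and gives 2400 nM. Among the compounds with values here, the only other measured compound, compound 2 `O=S(=O)(NCCNC(=S)Nc1cc(C(F)(F)F)cc(C(F)(F)F)c1)c1ccc(-c2ccccc2Oc2ccc(O)c(O)c2)s1`, gives 2600 nM in this assay; these two numbers lie within the usual scatter of such measurements, so neither compound can be called the stronger binder. Compound 3 `O=S(=O)(NCCNC(=S)Nc1cc(C(F)(F)F)cc(C(F)(F)F)c1)c1sccc1-c1ccccc1Oc1ccc(O)c(O)c1` has not yet been measured. It differs from compound 1 in one place: hydrogen in place of isopropyl on an aromatic carbon. Within the data shown here, no pair of measured compounds shows this change by itself, so its effect cannot be read off directly. Compound 2 also lacks an isopropyl group and gives 2600 nM, which suggests the group is not essential here. The step is therefore expected to be modest, at most a slight weakening, a 1.5-fold higher number from compound 1 to compound 3 (0.16 log units; within the scatter). For compound 3 in this assay the estimate is 3500 nM, with a likely range from 1500 nM to 9000 nM.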

Compound 3, inhibition constant: 5600 nM
Compound 3: middle estimate off by 1.6-fold (0.20 log units), on the low side, within the range that was stated.
By their numbers in this assay, from the lowest: compounds 1 and 2 (each within the scatter of the next); then compound 3.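

In this assay the change from isopropyl to hydrogen, on the carbon para to the 3,4-dihydroxyphenoxy group, gives a 2.3-fold higher number from compound 1 to compound 3 (0.37 log units; beyond the scatter) and so this position does respond to the change, though only modestly. Within the data shown here, compound 2 also lacks the isopropyl group but differs from compound 1 elsewhere too, so only this pair isolates the group's contribution, and on this core isopropyl goes with the lower number. Nothing measured here bears on why the number moves.

Only isopropyl and hydrogen are shown on this carbon, so it remains open whether a methyl, a tert-butyl, a methoxy or an amine there would give a lower or a higher number. Going by these compounds, whether the same step would appear on other cores also remains open.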